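Methoxy for chloro on the indole arm of the core

The source may hold more compounds than are shown below. What is called first, only, known or untested is meant among the compounds shown, and "the series" means these compounds.

Measured so far:
Compound 1 `COc1ccc2[nH]cc(-c3cnc(N(C)[C@@H]4C[C@H]5O[C@@](C)([C@@H]4OC)n4c6ccccc6c6c7c(c8c9ccccc9n5c8c64)C(=O)NC7)s3)c2c1`, in a functional assay on HL-60 cells (Homo sapiens) for antiproliferative activity, read by CellTiter-Glo, with a stated time of 72 h; on this read-out higher numbers stand for weaker inhibition and lower numbers for stronger inhibition: > 10000 nM
Compound 2 `CO[C@@H]1[C@H](N(C)c2ncc(-c3c[nH]c4ccc(Cl)cc34)s2)C[C@H]2O[C@]1(C)n1c3ccccc3c3c4c(c5c6cc(Br)ccc6n2c5c31)C(=O)NC4`, in this assay: > 10000 nM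

Compound 2 stands at a limit of this assay, not at a number. Compound 1 likewise sits at a limit, so neither compound can be placed relative to the other; they only show that both are weak. Among the measured compounds shown here, no step between measured compounds is available.

Compound 3 `COc1ccc2[nH]cc(-c3cnc(N(C)[C@@H]4C[C@H]5O[C@@](C)([C@@H]4OC)n4c6ccccc6c6c7c(c8c9cc(Br)ccc9n5c8c64)C(=O)NC7)s3)c2c1` keeps the bromo-bearing core of compound 2 and changes the indole arm: methoxy in place of chloro on an aromatic carbon.

For the measured compounds named here, the only evidence bearing on this change is the limit of > 10000 nM in this assay, at which 2 of the 2 values shown sit, and on that basis the step from compound 2 to compound 3 is expected to be none beyond the scatter, a number no higher from compound 2 to compound 3 (the limit leaves the size open). Compound 3 is therefore expected to give about 10000 nM, somewhere between 4000 nM and 30000 nM, most likely reported again only as a limit.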

Compound 3, half-maximal inhibitory concentration: > 10000 nM
Compound 3: no number, only a limit; the forecaster's own chance of this, stated with the estimate: 85%; the middle value lies on the limit itself.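

In this assay compound 3 gives > 10000 nM, a limit and not a number, so neither its step from compound 2 nor its step from compound 1 can be read. On these data alone, whether methoxy, chloro or the bromo on the core changes activity at all stays open.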